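The compounds below may be only part of what the source reports. "The series", "measured", "known", "first", "only" and "open" are said of these compounds alone.

In an ADME assay on HFF cells (Homo sapiens) for cytotoxicity, read by neutral red uptake (a lower number here means that less compound is tolerated, a higher number that more compound is tolerated), compound 2 (`Nc1ncnc2c1ncn2/C=C1/C[C@@H]1[C@H](O)CO`) gives > 300000 nM as its reading, which is a limit of the assay and not a number. Going by the values given here, compound 1 (`Nc1nc2c(ncn2/C=C2\C[C@@H]2[C@H](O)CO)c(=O)[nH]1`), the only other measured compound, gives > 300000 nM as its reading, which is also a limit. Compound 2 therefore has no numerical position in the series, and the measured pair shows only the limit of > 300000 nM in this assay, at which 2 of the 2 values shown sit, as its common result.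

Compound 3 (`Nc1ncnc2c1ncn2/C=C1/C[C@@H]1[C@@H](O)CO`) differs from compound 2 in configuration alone (the two compounds have the same atoms and bonds and differ only in configuration as drawn: 1 of 3 stereo elements differ; a stereocentre at a saturated chain carbon is drawn S in compound 2 and R in compound 3). A stereocentre at a saturated chain carbon is drawn S in compound 2 and R in compound 3, and the atoms and bonds stay the same. Among the compounds with values here, no measured step shows what such a change does, so the expectation has only the two limits to rest on. With compound 2 reading > 300000 nM as a limit, no shift beyond the usual scatter is expected, in either direction. The expected size is a number no higher from compound 2 to compound 3 (the limit leaves the size open) as a working figure. For compound 3 the estimated value is 300000 nM (expected range 120000 nM to 400000 nM), and a report as a limit is the likeliest outcome.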

Compound 3, half-maximal cytotoxic concentration: > 300000 nM
Compound 3: only a limit was reported; the forecaster's own chance of this, stated with the estimate: 85%; the middle value sits exactly at the limit.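

In this assay compound 2 and compound 3 both sit at a limit of the assay and not at a number, so no step can be read between them: the limit of > 300000 nM in this assay, at which 3 of the 3 values shown sit.

The compounds shown leave open whether drawing the stereocentre at the saturated chain carbon as S or R changes the reading at all, and where any of these compounds would give an actual number.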